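A ring swap at the end of the chain

The compounds below may be only part of what the source reports. "The series", "measured", "known", "first", "only" and "open" are said of these compounds alone.

Values in a functional assay on HT-29 cells (Homo sapiens) for inhibition, read by MTT assay, with a stated time of 3 days; a higher number here means a weaker inhibitor, a lower number a stronger inhibitor
compound 1 `C/C=C/COc1cc(/C=C\c2cc(OC)c(OC)c(OC)c2)ccc1OC` 161000 nM
compound 2 `COc1ccc(/C=C\c2cc(OC)c(OC)c(OC)c2)cc1OCc1ccccc1` 39000 nM
compound 3 `COc1cccc(/C=C/CCCOc2cc(/C=C\c3cc(OC)c(OC)c(OC)c3)ccc2OC)c1` 25000 nM

Compound 3 stands level with compound 2 within the scatter (a 1.6-fold lower number from compound 2 to compound 3 (0.19 log units; within the scatter)) and clearly under compound 1 (a 6.4-fold lower number from compound 1 to compound 3 (0.81 log units; beyond the scatter)). Compound 4 `COc1ccc(/C=C\c2cc(OC)c(OC)c(OC)c2)cc1OCCC/C=C/c1ccc(F)cc1` has 4-fluorophenyl in place of 3-methoxyphenyl on a double-bonded chain carbon bound to a double-bonded chain carbon. Going by the values given here, no measured step makes this swap alone. Replacing prop-1-en-1-yl gave only modest steps (a 4.1-fold lower number from compound 1 to compound 2 (0.62 log units; beyond the scatter) and a 6.4-fold lower number from compound 1 to compound 3 (0.81 log units; beyond the scatter)), and the much larger exchange of phenyl for the whole 4-(3-methoxyphenyl)but-3-en-1-yl stayed within the scatter (again a 1.6-fold lower number from compound 2 to compound 3 (0.19 log units; within the scatter)). No step beyond the scatter is therefore expected in this assay, and the estimate amounts to a 1.2-fold higher number from compound 3 to compound 4 (0.08 log units; within the scatter) as the expected change. Compound 4 is expected near 30000 nM, with an estimated range from 11000 nM to 80000 nM in repeat measurements.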

Compound 4, half-maximal inhibitory concentration: 98000 nM
Beside the measured number, compound 4's estimate is 3.3-fold (0.51 log units) below it, outside the stated range (above it).
By their numbers in this assay, from the lowest: compounds 3 and 2 (each within the scatter of the next); then compounds 4 and 1 (each within the scatter of the next).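

In this assay the aryl group at the end of the chain matters: 4-fluorophenyl in place of 3-methoxyphenyl gives a 3.9-fold higher number from compound 3 to compound 4 (0.59 log units; beyond the scatter) as a step of its own. The long chain therefore does not set the value alone: carrying 4-fluorophenyl, it gives a 2.5-fold higher number from compound 2 to compound 4 (0.40 log units; beyond the scatter) when it replaces phenyl and a 1.6-fold lower number from compound 1 to compound 4 (0.22 log units; within the scatter) when it replaces prop-1-en-1-yl. Nothing available explains this shift. Because the methoxy group leaves as the fluorine enters, their separate contributions remain unresolved. Unsubstituted phenyl, 3-fluorophenyl or 4-methoxyphenyl on this chain could separate them.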